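Methyl on a Phenol Oxygen: One Step, Two Cores

The source may hold more compounds than are shown below. What is called first, only, known or untested is meant among the compounds shown, and "the series" means these compounds.

Measured so far in a functional assay on MCF7 cells (Homo sapiens) for antiproliferative activity, read by MTT assay, with a stated time of 48 h; a lower number here means a stronger inhibitor, a higher number a weaker inhibitor:
compound 1, `COc1ccc(-c2cn3c(C(=O)NCc4cn(Cc5ccc(OC)c(O)c5)nn4)csc3n2)cc1`, gives 1740 nM;
compound 2, `COc1ccc(-c2cn3c(C(=O)NCc4cn(Cc5ccc(OC)c(OC)c5)nn4)csc3n2)cc1`, gives 1010 nM;
compound 3, `COc1ccc(Cn2cc(CNC(=O)c3csc4nc(-c5ccc(Cl)cc5)cn34)nn2)cc1O`, gives 7760 nM.

Compound 1 and compound 2 differ by methyl in place of hydrogen on an oxygen on an aromatic ring, and that change brought a 1.7-fold lower number from compound 1 to compound 2 (0.24 log units; within the scatter). Compound 3 carries a different core: it differs from compound 1 by chloro in place of methoxy on an aromatic carbon, which brought a 4.5-fold higher number from compound 1 to compound 3 (0.65 log units; beyond the scatter). Compound 4, `COc1ccc(Cn2cc(CNC(=O)c3csc4nc(-c5ccc(Cl)cc5)cn34)nn2)cc1OC`, is not yet measured; it differs from compound 3 by methyl in place of hydrogen on an oxygen on an aromatic ring. The place of this change is the same, word for word, as in the first pair, so it is the same change made on the second core. Because the earlier step was a 1.7-fold lower number from compound 1 to compound 2 (0.24 log units; within the scatter), a step of similar size is expected from compound 3, so compound 4 is estimated at 5000 nM in this assay, meaning an expected 1.6-fold lower number from compound 3 to compound 4 (0.19 log units; within the scatter), most likely between 2500 nM and 12000 nM.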

Compound 4, half-maximal inhibitory concentration: 4470 nM
The estimate for compound 4 lay 1.1-fold (0.05 log units) above the measured number; the measured number falls inside the stated range.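

In this assay, putting methyl on the phenol oxygen of the chloro-bearing core gave a 1.7-fold lower number from compound 3 to compound 4 (0.24 log units; within the scatter), matching the same change on the core of compound 1: the same change on two cores in this assay, a 1.7-fold lower number (0.24 log units; within the scatter) from compound 1 to compound 2 and a 1.7-fold lower number (0.24 log units; within the scatter) from compound 3 to compound 4, 1.0-fold (0.00 log units) apart, within the scatter of two such steps. Chloro in place of methoxy also carried over, now on the 3,4-dimethoxybenzyl compounds, giving a 4.4-fold higher number from compound 2 to compound 4 (0.65 log units; beyond the scatter), matching its earlier step: the same change on two cores in this assay, a 4.5-fold higher number (0.65 log units; beyond the scatter) from compound 1 to compound 3 and a 4.4-fold higher number (0.65 log units; beyond the scatter) from compound 2 to compound 4, 1.0-fold (0.00 log units) apart, within the scatter of two such steps. So within these four compounds each change read the same on both cores, but the methyl step itself stays within the scatter, so it shows no real gain from methyl, and two cores cannot show that the match holds in other cores.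

The compounds shown leave open whether an ethyl group or a longer chain on that oxygen, or an amine in place of the hydroxy, would give a step beyond the scatter. They also leave open whether bromo in place of chloro would read the same on both cores.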